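The compounds below may be only part of what the source reports. "The series", "measured", "known", "first", "only" and "open" are said of these compounds alone.

Compound 1 `COc1cc(OCc2cccc(-c3ccc(C#N)cc3)c2)c2cc(-c3cn4nc(OC)sc4n3)oc2c1` and compound 3 `COc1ccc(-c2cccc(COc3cc(OC)cc4oc(-c5cn6nc(OC)sc6n5)cc34)c2)nc1` share a core, and compound 3 differs from compound 1 by a single exchange on one aromatic carbon: 5-methoxypyridin-2-yl in place of 4-cyanophenyl on an aromatic carbon. For compound 1 no single number is available in a functional assay on HEK293 cells for antagonist activity at proteinase-activated receptor 4 (Homo sapiens), read by FLIPR and calcium flux, with a stated time of 30 min (a lower number here means a stronger inhibitor, a higher number a weaker inhibitor), since the entry for compound 1 reads "nd" (no result reported). The only measured point in this assay comes from compound 2 `COc1cc(OCc2csc(-c3ccc(C(F)(F)F)cc3)n2)c2cc(-c3cn4nc(OC)sc4n3)oc2c1`, which is built on the same core with a different linking ring; in this assay compound 2 gives 1.3 nM. Among the compounds with values here, no step between two measured compounds is on record, so the size of the change from compound 1 to compound 3 cannot be read from data, and any step is expected to stay small, with no clear direction beyond the scatter. Compound 3 is expected to give about 5 nM in this assay, within a range of 1 nM to 40 nM.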

Compound 3, half-maximal inhibitory concentration: 0.5 nM
Estimate against measurement, compound 3: 10-fold (1.00 log units) above, and the stated range ends above it.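

Within the data shown here, compound 1 has no single number in this assay, so no step from compound 1 to compound 3 can be read. The compounds shown leave open how far exchanging 4-cyanophenyl for 5-methoxypyridin-2-yl shifts inhibition. No further evidence bears on this result.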